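A few compounds are considered here, and "the series" means these few. Any claim that something is new, unique, unknown or untested is made for them only; others in the source may bear on it.

Among the measured compounds shown here, compound 3 `Cc1nn(C)c(C)c1-c1ccc(-c2nnc(N(C)Cc3ccc4nccn4c3)o2)c(F)c1` gives 12.6 nM in an assay on isolated protein for inhibition of tyrosine-protein kinase Mer (Homo sapiens), read by LC-MS (on this read-out lower numbers stand for stronger inhibition and higher numbers for weaker inhibition), the lowest of the three numbers measured so far. Compound 1 `Cc1nn(C)c(C)c1-c1ccc(-c2nnc(N(C)Cc3ccc4nccn4c3)o2)cc1` gives 31.6 nM in this assay, and compound 2 `Cc1noc(C)c1-c1ccc(-c2nnc(N(C)Cc3ccc4nccn4c3)o2)cc1` gives 200 nM. The two recorded steps are a 2.5-fold lower number from compound 1 to compound 3 (0.40 log units; beyond the scatter) and a 6.3-fold higher number from compound 1 to compound 2 (0.80 log units; beyond the scatter). Compound 4 `Cc1nn(C)c(C)c1-c1ccc(-c2nnc(N(C)Cc3ccc4nccn4c3)o2)c(Cl)c1` differs from compound 3 by chloro in place of fluoro on an aromatic carbon. For the measured compounds named here, no measured step exchanges one halogen for another; only a 2.5-fold lower number from compound 1 to compound 3 (0.40 log units; beyond the scatter) touches the same aromatic carbon, and it was modest. The step to compound 4 is therefore expected to be small, a 1.1-fold lower number from compound 3 to compound 4 (0.02 log units; within the scatter), possibly within the scatter. Compound 4 is estimated at 12 nM in this assay, with a range from 5 nM to 30 nM.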

Compound 4, half-maximal inhibitory concentration: 2.51 nM
For compound 4 the middle estimate is 4.8-fold (0.68 log units) above the measured one; measured number outside the range, below it.
By their numbers in this assay, from the lowest: compound 4; then compound 3; then compound 1; then compound 2.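

Exchanging one halogen for another at this aromatic carbon is not a neutral change in this assay: chloro in place of fluoro gives a 5.0-fold lower number from compound 3 to compound 4 (0.70 log units; beyond the scatter) and so the identity of the halogen matters, not only its presence. Against the hydrogen of compound 1, chloro gives a 13-fold lower number from compound 1 to compound 4 (1.10 log units; beyond the scatter) and this is the only step at this position printed as large. Nothing measured here accounts for the difference between the two halogens.

As far as these compounds go, whether bromo, methyl or trifluoromethyl at this aromatic carbon would follow chloro remains open. Also open, from the compounds shown here alone, is whether chloro has a similar effect when 3,5-dimethyl-1,2-oxazol-4-yl replaces 1,3,5-trimethyl-1H-pyrazol-4-yl.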